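The source may report more compounds than this note shows. Statements on the series, on what has been measured and on what is new or still open speak of the compounds shown alone.

Working notes on the amide series. Compound 1 `O=C(CCc1cccc2c1B(O)OC2)NC1CCCCC1` carries cyclohexyl on the amide nitrogen of the shared core. In a functional assay on HCT-116 cells (Homo sapiens) for antiproliferative activity, read by MTT assay, with a stated time of 72 h (a higher number here means a weaker inhibitor, a lower number a stronger inhibitor), compound 1 gives only a limit, > 100000 nM, so no number is known for it; it sits at the limit of > 100000 nM in this assay, at which 1 of the 3 values shown sits. The aryl amides do give numbers: compound 2 `CC(C)(C)c1ccc(NC(=O)CCc2cccc3c2B(O)OC3)cc1` gives 19000 nM in this assay, and compound 3 `CC(C)(C)OC(=O)NCc1ccc(NC(=O)CCc2cccc3c2B(O)OC3)cc1` gives 2300 nM. Among the compounds with values here, the one measured step, an 8.3-fold lower number from compound 2 to compound 3 (0.92 log units; beyond the scatter), swaps a group on an aromatic carbon and does not touch the cyclohexyl-to-aryl question; it shows only that within the aryl amides a change of substituent shifts the number by a modest amount. Compound 4 `O=C(CCc1cccc2c1B(O)OC2)Nc1cccc(Br)c1` is not yet measured; relative to compound 1 the change is 3-bromophenyl in place of cyclohexyl on an amide-type nitrogen. Within the data shown here, no measured step bears directly on this change, and the two aryl amides, compound 2 and compound 3, are the nearest guide. Compound 4 is expected to land among them, a step of an at least 6.6-fold lower number from compound 1 to compound 4 (0.82 log units; beyond the scatter) into the measurable range. The estimate for compound 4 is 15000 nM, with a range of 4000 nM to 60000 nM.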

Compound 4, half-maximal inhibitory concentration: 1400 nM
Estimate against measurement, compound 4: 11-fold (1.03 log units) above, and the stated range ends above it.
By their numbers in this assay, from the lowest: compounds 4 and 3 (each within the scatter of the next); then compound 2. At a limit, above all of these: compound 1.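

The change to 3-bromophenyl in place of cyclohexyl on an amide-type nitrogen gives an at least 71-fold lower number from compound 1 to compound 4 (1.85 log units; beyond the scatter) in this assay. Within the data shown here, this is the first measured step at this position, and it shows that the group on this nitrogen moves the number, which the earlier step, a swap of substituents on an aromatic carbon, could not show. The true size of the step stays unknown because compound 1 gives only a limit: the limit of > 100000 nM in this assay, at which 1 of the 4 values shown sits.

The compounds shown do not separate the contribution of the aromatic ring from that of the bromine, and a plain phenyl on this nitrogen would tell the two apart. They also give no reading on how an amine or a carboxylic acid on that ring would behave.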